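A few compounds are considered here, and "the series" means these few. Any claim that something is new, unique, unknown or untested is made for them only; others in the source may bear on it.

Measured in an ADME assay on L1210/0 cells (Mus musculus) for cytotoxicity, with a stated time of 48 h; a higher number here means a weaker inhibitor, a lower number a stronger inhibitor:
- compound 1 `O=C1O/C(=C\Cn2cc(I)c(=O)[nH]c2=O)C(OCc2ccccc2)=C1OCc1ccccc1`: 7500 nM
- compound 2 `O=c1[nH]c(=O)n([C@H]2C[C@H](O)[C@@H](CO)O2)cc1[N+](=O)[O-]`: 130 nM
- compound 3 `N#CSc1cn([C@H]2C[C@H](O)[C@@H](CO)O2)c(=O)[nH]c1=O`: 78900 nM

Among these three, compound 3 stands highest at 78900 nM in this assay, and thus is the weakest inhibitor of the set. Compound 4 `N#Cc1cn([C@H]2C[C@H](O)[C@@H](CO)O2)c(=O)[nH]c1=O` has cyano in place of cyanosulfanyl on an aromatic carbon.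

Among the measured compounds shown here, only one measured step bears on this change: a 610-fold higher number from compound 2 to compound 3 (2.78 log units; beyond the scatter). That large step replaced nitro with cyanosulfanyl, the group that now leaves. For the measured compounds named here, it shows that a change of this group can move the number widely, but no measured compound carries cyano, so it gives the direction only loosely. A moderate step to a lower number, smaller than that one, is therefore expected in this assay, with considerable uncertainty.

The estimate means an expected 3.9-fold lower number from compound 3 to compound 4 (0.60 log units; beyond the scatter). Compound 4 is expected at 20000 nM, with an estimated range from 2500 nM to 100000 nM.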

Compound 4, half-maximal inhibitory concentration: > 200000 nM
Compound 4: only a limit was reported (the forecaster's own chance of this, stated with the estimate: 20%); at least 10-fold (1.00 log units) between middle value and limit.
By their numbers in this assay, from the lowest: compound 2; then compound 1; then compound 3. At a limit, above all of these: compound 4.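

In this assay, compound 4 is reported only as a limit of the assay, not as a number: the limit of > 200000 nM in this assay, at which 1 of the 4 values shown sits. Cyano in place of cyanosulfanyl on this aromatic carbon gave an at least 2.5-fold higher number from compound 3 to compound 4 (0.40 log units; beyond the scatter), so compound 3, the highest of the earlier numbers, does not mark the top of the range for this position. Cyano in place of nitro gave an at least 1500-fold higher number from compound 2 to compound 4 (3.18 log units; beyond the scatter), a span wider than the earlier 610-fold higher number from compound 2 to compound 3 (2.78 log units; beyond the scatter), and nitro stands apart from both other groups at this position on the shared core.

On these data alone, how far compound 4 lies past its limit stays unknown, so both new steps have only a lower bound. As far as these compounds go, whether an amine or a carboxylic acid on this carbon would give a number near that of nitro or near that of cyano remains open.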